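Varying the aryl group on the ring nitrogen

The compounds below may be only part of what the source reports. "The series", "measured", "known", "first", "only" and "open" are said of these compounds alone.

Compound 1 `Cc1cc(=O)oc2cc(OCc3cn(-c4ccc(F)cc4)nn3)ccc12` and compound 2 `Cc1cc(C)cc(-n2cc(COc3ccc4c(C)cc(=O)oc4c3)nn2)c1` share a core and differ only in the group carried on an aromatic nitrogen of the five-membered ring. In an ADME assay on Huh-7 cells (Homo sapiens) for cytotoxicity, read by MTT assay, with a stated time of 72 h (a higher number here means that more compound is tolerated, a lower number that less compound is tolerated), compound 1 gives > 100 ug/mL, which is a limit of the assay rather than a measured number. In this assay compound 2 likewise gives > 100 ug/mL, again a limit. Because both values sit at the limit (the limit of > 100 ug/mL in this assay, at which 2 of the 2 values shown sit), the step that the two limits leave unreadable from compound 1 to compound 2 cannot be read in size or direction. Compound 2 thus stands at the top of the tested range, alongside compound 1, and no finer placement is possible. Compound 3 `Cc1ccc(-n2cc(COc3ccc4c(C)cc(=O)oc4c3)nn2)c(Cl)c1` is the next variation: 2-chloro-4-methylphenyl in place of 3,5-dimethylphenyl on an aromatic nitrogen. For the measured compounds named here, the only measured step at this position, a step that the two limits leave unreadable from compound 1 to compound 2, is unreadable, so nothing in the data points to a shift in this assay beyond the scatter for a change of this kind. Compound 3 is therefore expected to give 150 ug/mL, between 60 ug/mL and 400 ug/mL. For compound 3 the expected step is a step that the limit leaves unreadable from compound 2 to compound 3, with a high chance that again only a limit is reported.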

Compound 3, half-maximal cytotoxic concentration: > 100 ug/mL
Compound 3 was reported as a limit; the forecaster's own chance of this, stated with the estimate: 80%; the middle value does not contradict the limit.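

In this assay compound 3 gives > 100 ug/mL, which is a limit and not a measured number. For the compounds shown here, no step among compound 1, compound 2 and compound 3 can be read in size or direction, because all three values sit at the same limit: the limit of > 100 ug/mL in this assay, at which 3 of the 3 values shown sit. Still open, going by these compounds, is the concentration at which each compound would harm the cells, and whether these aryl groups differ at all in this assay.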